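The source may report more compounds than this note shows. Statements on the series, on what has been measured and on what is new or still open speak of the compounds shown alone.

Of the compounds shown here, two built on one shared core have been measured in an assay on HEK293 cells for displacement of a labelled ligand from adenosine receptor A2b (Homo sapiens), with a stated time of 30 min; a lower number here means a stronger inhibitor, a higher number a weaker inhibitor. Compound 1 `CCOC(=O)C1=C(C)N/C(=N\C#N)NC1c1cccs1` gives 51 nM in this assay, while compound 2 `CCOC(=O)C1=C(C)N/C(=N\C#N)NC1c1ccco1` gives 900 nM. Compound 2 therefore stands highest of the two numbers, set apart by the step of an 18-fold higher number from compound 1 to compound 2 (1.25 log units; beyond the scatter). Compound 3 `CCOC(=O)C1=C(C)N/C(=N\C#N)NC1c1ccoc1` is the next member. It differs from compound 2 by furan-3-yl in place of furan-2-yl on a saturated ring carbon. Within the data shown here, no measured step in this assay covers that kind of change: the single step known, an 18-fold higher number from compound 1 to compound 2 (1.25 log units; beyond the scatter), exchanges one five-membered ring for another and says nothing about going from furan-2-yl to furan-3-yl. Among the measured compounds shown here, with no direct precedent, compound 3 is expected to remain close to compound 2, the step of a 1.1-fold higher number from compound 2 to compound 3 (0.05 log units; within the scatter) being estimated to fall within the usual scatter. Compound 3 is accordingly estimated at 1000 nM in this assay, with a range from 300 nM to 4000 nM.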

Compound 3, inhibition constant: 102 nM
Beside the measured number, compound 3's estimate is 9.8-fold (0.99 log units) above it, and the stated range ends above it.
By their numbers in this assay, from the lowest: compounds 1 and 3 (each within the scatter of the next); then compound 2.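

Moving the attachment of the furan ring on this saturated ring carbon, with the atoms unchanged, gives an 8.8-fold lower number from compound 2 to compound 3 (0.95 log units; beyond the scatter) in this assay, so how the ring is joined to the shared core matters here, not only which ring is present. The large step seen earlier from the thiophen-2-yl compound therefore does not hold for furan rings in general: compound 3 goes against it, with a 2.0-fold higher number from compound 1 to compound 3 (0.30 log units; within the scatter). Nothing available explains the difference between the two furan isomers. From the compounds shown here alone, it remains open whether thiophen-3-yl would differ from thiophen-2-yl as furan-3-yl differs from furan-2-yl. Going by these compounds, how a phenyl ring or an open chain such as propyl would compare at this saturated ring carbon also remains open.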